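Bromopyridyl cyanoacrylamides: swapping the aryl group of compound 1

A few compounds are considered here, and "the series" means these few. Any claim that something is new, unique, unknown or untested is made for them only; others in the source may bear on it.

- compound 1 `C[C@H](NC(=O)/C(C#N)=C/c1cccc(Br)n1)c1ccc(Br)cc1` gives 1500 nM
- compound 2 `N#C/C(=C\c1cccc(Br)n1)C(=O)N[C@@H]1CCc2ccccc21` gives 2000 nM
- compound 3 `N#C/C(=C\c1cccc(Br)n1)C(=O)N[C@@H](CO)c1ccccc1` gives 2800 nM

In a functional assay on MM1 cells (Homo sapiens) for antiproliferative activity, read by MTT assay, with a stated time of 72 h (on this read-out higher numbers stand for weaker inhibition and lower numbers for stronger inhibition), compound 1 stands within the scatter of both other compounds, so the three values do not separate. Compound 4 `COc1cccc([C@H](C)NC(=O)/C(C#N)=C/c2cccc(Br)n2)c1` carries 3-methoxyphenyl in place of 4-bromophenyl on a saturated chain carbon bound to an amide-type nitrogen and a saturated chain carbon. For the measured compounds named here, no single-place step among the measured compounds is available to size this change. Compound 2 at 2000 nM and compound 3 at 2800 nM carry other groups on the amide nitrogen and still sit within the scatter of compound 1, so no step beyond the scatter is expected in this assay for compound 4. The expected step is a 1.5-fold higher number from compound 1 to compound 4 (0.17 log units; within the scatter) on this estimate. Compound 4 is estimated at 2200 nM with an expected range from 1000 nM to 5000 nM in this series.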

Compound 4, half-maximal inhibitory concentration: 2400 nM
Beside the measured number, compound 4's estimate is 1.1-fold (0.04 log units) below it, and the stated range covers the measured number.
By their numbers in this assay, from the lowest: compounds 1, 2, 4 and 3 (each within the scatter of the next).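

The step of a 1.6-fold higher number from compound 1 to compound 4 (0.20 log units; within the scatter) in this assay is the only size available for this position, and it lies within the scatter. Exchanging 4-bromophenyl for 3-methoxyphenyl on this saturated chain carbon, which also brings in a hydrogen-bond acceptor, therefore does not separate the two compounds on this read-out. No measured evidence bears on this result.

Still open, going by these compounds, is whether any group at this place moves the number beyond the scatter, for example an aminophenyl or carboxyphenyl group, or a longer chain in place of the aryl ring.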